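A few compounds are considered here, and "the series" means these few. Any claim that something is new, unique, unknown or untested is made for them only; others in the source may bear on it.

In a functional assay on MGC-803 cells (Homo sapiens) for inhibition, read by sulforhodamine B assay (a higher number here means a weaker inhibitor, a lower number a stronger inhibitor), compound 1 `O=C1C(Nc2ccc(Br)cc2)=CC(=O)c2c1nc1n2[C@H]2OC[C@@H](O)[C@H]2OC1` gives 2020 nM and compound 3 `CCOc1ccc(NC2=CC(=O)c3c(nc4n3[C@H]3OC[C@@H](O)[C@H]3OC4)C2=O)cc1` gives 2090 nM, the two level within the scatter. Compound 2 `O=C1C(N2CCCC2)=CC(=O)c2c1nc1n2[C@H]2OC[C@@H](O)[C@H]2OC1` reports only a limit, > 16000 nM.

Compound 4 `COc1cccc(NC2=CC(=O)c3c(nc4n3[C@H]3OC[C@@H](O)[C@H]3OC4)C2=O)c1` carries 3-methoxyphenyl in place of 4-ethoxyphenyl on an amine nitrogen.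

The closest measured change is a 1.0-fold higher number from compound 1 to compound 3 (0.01 log units; within the scatter), which keeps an aromatic ring on the amine nitrogen and stays within the scatter. The other, an at least 7.9-fold higher number from compound 1 to compound 2 (0.89 log units; beyond the scatter), lies beyond the scatter, but there pyrrolidin-1-yl replaces the whole (4-bromophenyl)amino group, a change of another kind. No shift beyond the scatter is therefore expected in this assay, and no direction is favoured. The estimated change is a 1.2-fold higher number from compound 3 to compound 4 (0.08 log units; within the scatter). Compound 4 is expected at 2500 nM, within an estimated range of 1000 nM to 6500 nM.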

Compound 4, half-maximal inhibitory concentration: 1790 nM
For compound 4 the middle estimate is 1.4-fold (0.15 log units) above the measured one; measured number inside the range.
By their numbers in this assay, from the lowest: compounds 4, 1 and 3 (each within the scatter of the next). At a limit, above all of these: compound 2.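

In this assay, 3-methoxyphenyl in place of 4-ethoxyphenyl on the amine nitrogen leaves the number level (a 1.2-fold lower number from compound 3 to compound 4 (0.07 log units; within the scatter)), and 3-methoxyphenyl in place of 4-bromophenyl does the same (a 1.1-fold lower number from compound 1 to compound 4 (0.05 log units; within the scatter)), so all three substituted phenyl groups shown sit level at this position. The (3-methoxyphenyl)amino group also stands clear of pyrrolidin-1-yl (an at least 8.9-fold lower number from compound 2 to compound 4 (0.95 log units; beyond the scatter)). Compound 2 gives only a limit: the limit of > 16000 nM in this assay, at which 1 of the 4 values shown sits.

Going by these compounds, whether a phenyl ring carrying a carboxylic acid or an amine stays level remains open. So does the behaviour of a benzyl group on the amine nitrogen.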